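The source may report more compounds than this note shows. Statements on the series, on what has been measured and on what is new or still open speak of the compounds shown alone.

Measured compounds:
compound 1, `COc1cc(/C=C/C(=O)c2c(OC)cc(O)c(CC=C(C)C)c2O)ccc1O`: 21700 nM
compound 2, `COc1cc(O)c(CC=C(C)C)c(O)c1C(=O)/C=C/c1ccc(O)c(O)c1`: 15200 nM
compound 3, `COc1cc(OC)c(C(=O)/C=C/c2ccc(O)c(O)c2)c(OC)c1`: 27500 nM

All three numbers come from a functional assay on HepG2 cells (Homo sapiens) for inhibition, read by MTT assay, with a stated time of 72 h; on this read-out lower numbers stand for stronger inhibition and higher numbers for weaker inhibition. Compound 3 stands highest of the three, but its distance to compound 1 and to compound 2 lies within the scatter, so no order among them can be read from these values.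

Compound 2 and compound 1 differ in one place: methyl in place of hydrogen on an oxygen on an aromatic ring. The step of a 1.4-fold higher number from compound 2 to compound 1 (0.15 log units; within the scatter) is within the scatter, so on this evidence the change leaves the read-out essentially where it was.

Compound 4, `COc1cc(OC)c(C(=O)/C=C/c2ccc(O)c(OC)c2)c(OC)c1`, has not yet been measured in this assay. Among the measured compounds shown here, it differs from compound 3 by methyl in place of hydrogen on an oxygen on an aromatic ring, the same change, at a place described in the same words, as the one from compound 2 to compound 1. The difference between the cores of compound 2 and compound 3 is not broken down here. Because a 1.4-fold higher number from compound 2 to compound 1 (0.15 log units; within the scatter) was within the scatter, the step expected for compound 4 is also small, a 1.3-fold higher number from compound 3 to compound 4 (0.10 log units; within the scatter). Compound 4 is accordingly estimated at 35000 nM, with a likely range from 15000 nM to 80000 nM.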

Compound 4, half-maximal inhibitory concentration: 17000 nM
Compound 4: middle estimate off by 2.1-fold (0.31 log units), on the high side; measured number inside the range.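

In this assay, the change from hydroxy to methoxy on the core of compound 3 gives a 1.6-fold lower number from compound 3 to compound 4 (0.21 log units; within the scatter). Although the two steps point in opposite directions, they do not differ beyond what repeated measurements would allow: the same change on two cores in this assay, a 1.4-fold higher number (0.15 log units; within the scatter) from compound 2 to compound 1 and a 1.6-fold lower number (0.21 log units; within the scatter) from compound 3 to compound 4, 2.3-fold (0.36 log units) apart, within the scatter of two such steps. Across these two cores, the change can therefore be carried over as one that leaves the read-out essentially where it stood, but this does not show that it would behave the same way on any other core, and steps this small cannot reveal a modest dependence on the core.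

The compounds shown have only hydrogen or methyl on that oxygen, which leaves open what a longer chain there, or an amine in place of the hydroxy, would do to the read-out. Every step shown lies within the scatter, so it also remains open whether any single change in this series can move the number beyond it.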